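A few compounds are considered here, and "the series" means these few. Any claim that something is new, unique, unknown or untested is made for them only; others in the source may bear on it.

Measured compounds:
Compound 1 `O=S(=O)(c1ccccc1)c1nc2ccccc2nc1N1CCCC1`: 34800 nM
Compound 2 `Cc1ccc(S(=O)(=O)c2nc3ccccc3nc2N2CCCC2)cc1`: > 50000 nM, a limit of the assay

Both compounds were tested in a functional assay on A549 cells (Homo sapiens) for cytotoxicity, read by MTT assay, with a stated time of 72 h; a higher number here means a weaker inhibitor, a lower number a stronger inhibitor. Compound 2 has no number there and stands only at a limit, > 50000 nM. For the measured compounds named here, compound 1 gives the only true number, 34800 nM.

The next compound is compound 3 `COc1ccc(S(=O)(=O)c2nc3ccccc3nc2N2CCCC2)cc1`. It carries methoxy in place of methyl on an aromatic carbon, para to a large group, changing 4-methylphenyl to 4-methoxyphenyl: methoxy in place of methyl on an aromatic carbon.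

Going by the values given here, only one measured step bears on this change, and it is a methyl in place of hydrogen on an aromatic carbon: an at least 1.4-fold higher number from compound 1 to compound 2 (0.15 log units; that floor lies within the scatter). Among the compounds with values here, its floor lies within the scatter, and no measured step shows what a methoxy does in this assay. No step beyond the scatter is therefore expected, and no direction can be assigned with confidence. The expected step is an at least 1.1-fold lower number from compound 2 to compound 3 (0.07 log units; that floor lies within the scatter). The estimate rests on compound 1 at 34800 nM and stays in the same weak range. For compound 3 the estimated value is 42000 nM, with an expected range from 20000 nM to 80000 nM.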

Compound 3, half-maximal inhibitory concentration: > 50000 nM
Compound 3: no number, only a limit; the forecaster's own chance of this, stated with the estimate: 45%; middle value at least 1.1-fold (0.07 log units) away from the limit.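

In this assay compound 3 gives > 50000 nM, which is a limit of the assay and not a number, so a second group on this aromatic carbon, para to a large group, has also failed to give a readable value. With methoxy in place of hydrogen, the result is an at least 1.4-fold higher number from compound 1 to compound 3 (0.15 log units; that floor lies within the scatter), so neither this step nor the earlier one with methyl shows a change beyond the scatter. The step from methyl to methoxy cannot be read, because both compounds rest on the same ceiling of the assay: the limit of > 50000 nM in this assay, at which 2 of the 3 values shown sit.

On these data alone, whether methyl and methoxy differ at all in this assay remains open, and so does whether any group at this position moves the value beyond the scatter from that of the unsubstituted compound 1. An amine or a carboxylic acid on this carbon could test this, provided it gave a true number rather than another limit.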